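Notes on the vinylcarbonyl analogue of the amide series

A few compounds are considered here, and "the series" means these few. Any claim that something is new, unique, unknown or untested is made for them only; others in the source may bear on it.

Compound 2 `CCCCC(O)c1cccc(NC(=O)CCCl)c1` carries a ((2-chloroethyl)carbonyl)amino group on the shared core. In a functional assay on MCF7 cells (Homo sapiens) for antiproliferative activity, with a stated time of 48 h (on this read-out higher numbers stand for weaker inhibition and lower numbers for stronger inhibition), compound 2 gives > 100000 nM, which is a limit of the assay and not a number. Compound 1 `CCCCC(O)c1cccc(NC(=O)NCCCCl)c1` has a (3-chloropropyl)amino group on the carbonyl carbon instead; in this assay compound 1 gives > 100000 nM, again a limit. Compound 3 `CCCCC(OC)c1cccc(NC(=O)CCCl)c1` bears a methyl in place of hydrogen on the oxygen on the saturated carbon; in this assay compound 3 gives > 100000 nM, also a limit. Compound 2 thus stands at the limit together with the other two, as summed up by the limit of > 100000 nM in this assay, at which 3 of the 3 values shown sit. The step that the two limits leave unreadable from compound 1 to compound 2 and the step that the two limits leave unreadable from compound 2 to compound 3 give no size. Compound 4 `C=CC(=O)Nc1cccc(C(O)CCCC)c1` differs from compound 2 by vinyl in place of 2-chloroethyl on a carbonyl carbon. Going by the values given here, no measured step touches the carbonyl substituent in this way, and the two known steps carry no readable size, so nothing points in either direction. Among the compounds with values here, with only three values at the limit to rest on, the step of an at least 1.6-fold lower number from compound 2 to compound 4 (0.22 log units; that floor lies within the scatter) is expected to keep compound 4 near that limit. Compound 4 is estimated at 60000 nM, with a range from 10000 nM to 200000 nM.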

Compound 4, half-maximal inhibitory concentration: > 100000 nM
Compound 4 gave a limit, no number (the forecaster's own chance of this, stated with the estimate: 60%); middle value at least 1.6-fold (0.22 log units) away from the limit.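

In this assay, compound 4 gives > 100000 nM, a limit of the assay and not a number. No new step can be read for compound 4 against compound 1 or compound 2, and the series sits wholly at the limit: the limit of > 100000 nM in this assay, at which 4 of the 4 values shown sit.

The compounds shown leave open whether any change on the carbonyl carbon or the oxygen alters the result in this assay.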